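This account rests on a few compounds, and the source may have more. Where it says the series, first, only, none or still open, it means among the compounds named here.

In a functional assay on HCT-116 cells (Homo sapiens) for cytotoxicity, read by MTT assay, with a stated time of 72 h (a lower number here means a stronger inhibitor, a higher number a weaker inhibitor), compound 1 `CN1CCN(CCCCn2c3c(c4ccccc42)C(=O)c2c[n+]([O-])c4ccccc4c2C3=O)CC1` gives 10 nM, compound 2 `CCCCN1CCN(CCCCn2c3c(c4ccccc42)C(=O)c2c[n+]([O-])c4ccccc4c2C3=O)CC1` gives 1920 nM and compound 3 `CN1CCN(CCCn2c3c(c4ccccc42)C(=O)c2c[n+]([O-])c4ccccc4c2C3=O)CC1` gives 560 nM, the second highest of these three numbers. Compound 4 `O=C1c2c[n+]([O-])c3ccccc3c2C(=O)c2c1c1ccccc1n2CCN1CCCCC1` differs from compound 3 thus: piperidin-1-yl in place of (4-methylpiperazin-1-yl)methyl on a saturated chain carbon, two bonds along the chain from an aromatic nitrogen. In effect, 3-(4-methylpiperazin-1-yl)propyl becomes the shorter 2-(piperidin-1-yl)ethyl. A shorter chain brought a large rise in a 56-fold higher number from compound 1 to compound 3 (1.75 log units; beyond the scatter), yet the modest 3.4-fold lower number from compound 2 to compound 3 (0.54 log units; beyond the scatter) runs the other way, though the butyl group also goes there. For the measured compounds named here, the large 190-fold higher number from compound 1 to compound 2 (2.28 log units; beyond the scatter) shows that this end of the molecule matters, but no measured step swaps the ring itself. A modest rise is therefore expected, namely a 1.8-fold higher number from compound 3 to compound 4 (0.25 log units; within the scatter). For compound 4 the estimate is 1000 nM, with an expected range of 200 nM to 5000 nM.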

Compound 4, half-maximal inhibitory concentration: 780 nM
Compound 4: the middle estimate sits 1.3-fold (0.11 log units) above what was measured; low and high end bracket the measured number.
By their numbers in this assay, from the lowest: compound 1; then compounds 3 and 4 (each within the scatter of the next); then compound 2.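

Replacing 3-(4-methylpiperazin-1-yl)propyl with the shorter 2-(piperidin-1-yl)ethyl gives a 1.4-fold higher number from compound 3 to compound 4 (0.14 log units; within the scatter), so changing both chain and ring together leaves compound 3 and compound 4 indistinguishable. The large gap to the best compound remains, with a 78-fold higher number from compound 1 to compound 4 (1.89 log units; beyond the scatter), while the 4-butylpiperazine compound stays modestly apart, with a 2.5-fold lower number from compound 2 to compound 4 (0.39 log units; beyond the scatter). Nothing measured here offers a reason for these numbers. On these data alone, because compound 4 alters chain and ring at once, the share of each remains open. A 2-(4-methylpiperazin-1-yl)ethyl chain or a 4-(piperidin-1-yl)butyl chain would separate the two.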